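The source may hold more compounds than are shown below. What is called first, only, known or untested is meant among the compounds shown, and "the series" means these compounds.

Measured in a functional assay on LOX IMVI cells (Homo sapiens) for cytotoxicity, read by MTT assay, with a stated time of 24 h; a higher number here means a weaker inhibitor, a lower number a stronger inhibitor:
Compound 1 `O=S(=O)(NCCCNc1nccc(-c2[nH]c(-c3ccccc3)nc2-c2ccc(F)c(O)c2)n1)c1cccc(F)c1`: 7890 nM
Compound 2 `O=S(=O)(NCCCNc1nccc(-c2[nH]c(-c3ccccc3)nc2-c2ccc(Cl)c(O)c2)n1)c1ccc(Br)cc1`: 15500 nM

In this assay, compound 2 gives 15500 nM, and this value lies within the scatter of compound 1 at 7890 nM, so the two numbers cannot be told apart. Compound 3 `O=S(=O)(NCCCNc1nccc(-c2[nH]c(-c3ccccc3)nc2-c2ccc(Cl)c(O)c2)n1)c1cccc(F)c1` keeps the rest of compound 2 and changes one group: 3-fluorophenyl in place of 4-bromophenyl on a sulfonyl sulfur. That is 3-fluorophenyl in place of 4-bromophenyl on a sulfonyl sulfur. Within the data shown here, no measured pair differs in this one place alone, so the size of the step cannot be read directly. Compound 1 already carries 3-fluorophenyl on a sulfonyl sulfur, and its 7890 nM suggests no large shift. The expected result is a 1.5-fold lower number from compound 2 to compound 3 (0.17 log units; within the scatter), which would stay within the scatter. For compound 3 the estimated value is 10500 nM, with an expected range from 5000 nM to 22000 nM.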

Compound 3, half-maximal inhibitory concentration: 33600 nM
Beside the measured number, compound 3's estimate is 3.2-fold (0.51 log units) below it; the whole stated range lies below it.
By their numbers in this assay, from the lowest: compounds 1 and 2 (each within the scatter of the next); then compound 3.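

In this assay, the sulfonyl sulfur position carries a measurable step: with the chloro group held constant, the change to 3-fluorophenyl gives a 2.2-fold higher number from compound 2 to compound 3 (0.34 log units; beyond the scatter). With 3-fluorophenyl held constant, the aromatic halogen also matters, as chloro in place of fluoro gives a 4.3-fold higher number from compound 1 to compound 3 (0.63 log units; beyond the scatter), so 3-fluorophenyl does not fix the value on its own, and compound 3 is the weakest of the three. Nothing given here accounts for either step.

From the compounds shown here alone, whether the sulfonyl step would keep its size with fluoro on the aromatic carbon remains open, since compound 1 and compound 2 differ in two places. Also open, going by these compounds, is how a methoxy group or a simple methyl on the sulfonyl sulfur would compare with these two aryl groups.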